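Replacing a fluorohydroxyphenyl with pyridin-4-yl

The source may report more compounds than this note shows. Statements on the series, on what has been measured and on what is new or still open speak of the compounds shown alone.

Compound 1 `Cc1c(C(=O)N/N=C\c2c(O)cccc2F)oc2cccc(O)c12` is the anchor here. In a functional assay on PC-3 cells (Homo sapiens) for inhibition (a lower number here means a stronger inhibitor, a higher number a weaker inhibitor), compound 1 gives 8050 nM, the lowest of the two plain numbers shown. Compound 2 `Cc1c(C(=O)N/N=C\c2cccc(F)c2O)oc2cccc(O)c12` gives 12700 nM in this assay, and the step of a 1.6-fold higher number from compound 1 to compound 2 (0.20 log units; within the scatter) stays within the usual scatter. Compound 3 `Cc1c(C(=O)N/N=C\c2cccnc2)oc2cccc(O)c12` is different: in this assay compound 3 reaches only >= 40000 nM, which is a limit of the assay rather than a measured number. The steps of an at least 4.9-fold higher number from compound 1 to compound 3 (0.69 log units; beyond the scatter) and an at least 3.1-fold higher number from compound 2 to compound 3 (0.49 log units; beyond the scatter) both go beyond the scatter, and both rest on that limit (the limit of >= 40000 nM in this assay, at which 1 of the 3 values shown sits).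

Compound 4 `Cc1c(C(=O)N/N=C\c2ccncc2)oc2cccc(O)c12` has not been measured. Its change from compound 1 is pyridin-4-yl in place of 2-fluoro-6-hydroxyphenyl on a carbon with a double bond to nitrogen. The closest measured guide is the step to compound 3, where a pyridin-3-yl likewise took the place of 2-fluoro-6-hydroxyphenyl and the number climbed to the limit. For compound 4 a step of similar size and direction is expected, a 5.0-fold higher number from compound 1 to compound 4 (0.70 log units; beyond the scatter), so compound 4 is estimated at 40000 nM, with a range from 15000 nM to 100000 nM.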

Compound 4, half-maximal inhibitory concentration: >= 40000 nM
Compound 4 ended at the assay's limit; the forecaster's own chance of this, stated with the estimate: 60%; the middle value sits exactly at the limit.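

In this assay, pyridin-4-yl at this carbon gives the same kind of loss as pyridin-3-yl: an at least 4.9-fold higher number from compound 1 to compound 4 (0.69 log units; beyond the scatter), and an at least 3.1-fold higher number from compound 2 to compound 4 (0.49 log units; beyond the scatter). The loss is therefore not confined to one pyridine, as both pyridines shown fall well short of the two fluorohydroxyphenyl compounds. The step between compound 3 and compound 4 cannot be read, and neither pyridine can be ranked over the other, since both values are limits rather than measured numbers: the limit of >= 40000 nM in this assay, at which 2 of the 4 values shown sit.

Each pyridine swap changes the ring and removes the hydroxyl and the fluorine at once, so these three changes cannot be told apart here. A plain phenyl or a 2-hydroxyphenyl at this carbon would be needed to show which of them carries the loss.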